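The compounds below may be only part of what the source reports. "The series", "measured", "known", "first", "only" and "open" are said of these compounds alone.

Compound 1, `OC[C@H]1O[C@@H](n2cnc3c(NCc4ccccc4Cl)ncnc32)[C@H](O)[C@@H]1O`, gives 64000 nM in a functional assay on K562 cells (Homo sapiens) for antiproliferative activity, with a stated time of 72 h; a lower number here means a stronger inhibitor, a higher number a weaker inhibitor. Compound 2, `OC[C@H]1O[C@@H](n2cnc3c(NCc4ccc(Cl)c(Cl)c4)ncnc32)[C@H](O)[C@@H]1O`, gives 10800 nM in this assay. Compound 3, `OC[C@H]1O[C@@H](n2cnc3c(NCc4ccc(F)c(F)c4F)ncnc32)[C@H](O)[C@@H]1O`, reaches only the assay limit of > 166000 nM.

Of the two plain numbers, compound 1 holds the higher one, as the step of a 5.9-fold lower number from compound 1 to compound 2 (0.77 log units; beyond the scatter) shows. Compound 4, `Cc1cccc(CNc2ncnc3c2ncn3[C@@H]2O[C@H](CO)[C@@H](O)[C@H]2O)c1O`, differs from compound 1 by 2-hydroxy-3-methylphenyl in place of 2-chlorophenyl on a saturated chain carbon bound to a nitrogen on an aromatic ring. Both measured steps touch this same place: a 5.9-fold lower number from compound 1 to compound 2 (0.77 log units; beyond the scatter) pointed down, while an at least 2.5-fold higher number from compound 1 to compound 3 (0.41 log units; beyond the scatter) pointed up, so a change here can move the number either way by a modest to large amount. Within the data shown here, no measured compound carries a hydroxyl on this ring, so the direction stays uncertain; a modest improvement is expected, a 3.2-fold lower number from compound 1 to compound 4 (0.51 log units; beyond the scatter). Compound 4 is estimated at 20000 nM, between 4000 nM and 100000 nM.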

Compound 4, half-maximal inhibitory concentration: 18000 nM
For compound 4 the middle estimate is 1.1-fold (0.05 log units) above the measured one, within the range that was stated.
By their numbers in this assay, from the lowest: compounds 2 and 4 (each within the scatter of the next); then compound 1. At a limit, above all of these: compound 3.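

The 2-hydroxy-3-methylphenyl group shows that this position does not need a halogen on the ring for the number to fall, giving a 3.6-fold lower number from compound 1 to compound 4 (0.55 log units; beyond the scatter). Against the 3,4-dichlorophenyl group the change gives a 1.7-fold higher number from compound 2 to compound 4 (0.22 log units; within the scatter), so the halogen-free ring and the dichlorinated ring cannot be told apart here. The step of an at least 9.2-fold lower number from compound 3 to compound 4 (0.96 log units; beyond the scatter) starts from a limit of the assay, not a number: the limit of > 166000 nM in this assay, at which 1 of the 4 values shown sits.

Still open, going by these compounds, is whether the hydroxyl or the methyl accounts for the step from the 2-chlorophenyl group. Also open, on these data alone, is what a methoxy group or an amine on this ring would give.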